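Swapping the Ring at the End of the Chain

This account rests on a few compounds, and the source may have more. Where it says the series, first, only, none or still open, it means among the compounds named here.

Of the compounds shown here, three have so far been measured in an ADME assay on microsomes from liver (Mus musculus) for metabolic stability, read by LC-MS, using NADPH, with a stated time of 45 min, tested at 0.5 uM; on this read-out higher numbers stand for fast clearance and lower numbers for slow clearance. Compound 1 `O=C1CCCN1CCCSc1nc2cc(Cl)ccc2o1` gives 51 mL/min/g. Compound 2 `COc1ccc2oc(SCCC(=O)N3CCCC3)nc2c1`, which has a different core and a different chain, gives 198 mL/min/g. Compound 3 `O=S1(=O)CCCN1CCCSc1nc2cc(Cl)ccc2o1` gives 115 mL/min/g, the second highest of the three numbers; its nearest neighbour is compound 2, within the usual scatter, and its furthest is compound 1, beyond it.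

Compound 4 `Clc1ccc2oc(SCCCN3CCCC3)nc2c1` has not yet been measured in this assay. It differs from compound 3 in one place: a group of 5 heavy atoms (4 carbon, 1 nitrogen; one five-membered non-aromatic ring with 1 hetero atom) in place of a group of 7 heavy atoms (3 carbon, 1 nitrogen, 2 oxygen, 1 sulfur; one five-membered non-aromatic ring with 2 hetero atoms), on a saturated chain carbon, three bonds along the chain from a sulfur.

Among the compounds with values here, only one measured step touches the same position, a 2.3-fold higher number from compound 1 to compound 3 (0.35 log units; beyond the scatter), a modest rise. The change from compound 3 to compound 4 moves away from the ring with two hetero atoms, but it does not return to the ring of compound 1, so that measured step cannot simply be read backwards. Compound 2 shares neither the core nor the end of the chain and offers no direct guidance. The expectation for compound 4 therefore rests on little, and a step of no clear direction beyond the scatter is expected, a 1.2-fold higher number from compound 3 to compound 4 (0.09 log units; within the scatter). Compound 4 is accordingly estimated to give 140 mL/min/g, within a range from 60 mL/min/g to 330 mL/min/g.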

Compound 4, intrinsic clearance in a liver preparation (reported as CLH), per the amount of preparation that the assay uses: 10.4 mL/min/g
The estimate for compound 4 lay 13-fold (1.13 log units) above the measured number; the measured number lies below the stated range.
By their numbers in this assay, from the lowest: compound 4; then compound 1; then compounds 3 and 2 (each within the scatter of the next).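

Within the data shown here, at this position, on a saturated chain carbon, three bonds along the chain from a sulfur, the end group matters far more in this assay than the one earlier step could show: pyrrolidin-1-yl brings an 11-fold lower number from compound 3 to compound 4 (1.04 log units; beyond the scatter) against the ring with two hetero atoms, and a 4.9-fold lower number from compound 1 to compound 4 (0.69 log units; beyond the scatter) against 2-oxopyrrolidin-1-yl. The second step is the cleanest comparison, since the two groups differ only by the carbonyl, and its loss alone takes the number beyond the scatter, in the opposite direction to a 2.3-fold higher number from compound 1 to compound 3 (0.35 log units; beyond the scatter) and further. Nothing in the data shown accounts for the size of these steps.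

As far as these compounds go, it remains open whether the low number is particular to pyrrolidin-1-yl or would also appear with another amine at the end of the same chain, such as dimethylamino, piperidin-1-yl or morpholin-4-yl. Also open, from the compounds shown here alone, is whether it would hold with a longer chain, or with pyrrolidin-1-yl on the core of compound 2, where the methoxy group stands in place of the chlorine.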